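Double-bond geometry step from compound 2 to compound 3

The source may report more compounds than this note shows. Statements on the series, on what has been measured and on what is new or still open speak of the compounds shown alone.

Measured so far:
compound 1 `COc1ccc(C(=O)/C(=C/C2CCCCC2)COC(=O)c2ccccc2)cc1`: 13700 nM
compound 2 `COc1ccc(C(=O)/C(=C/c2ccccc2Cl)COC(=O)c2ccccc2)cc1`: 9000 nM

In a functional assay on MCF7 cells (Homo sapiens) for inhibition, read by XTT assay, with a stated time of 48 h (a lower number here means a stronger inhibitor, a higher number a weaker inhibitor), compound 1 gives 13700 nM. In this assay compound 2 gives 9000 nM. For the measured compounds named here, the one step between them is a 1.5-fold lower number from compound 1 to compound 2 (0.18 log units; within the scatter), so compound 2 and compound 1 sit within the scatter of each other and no order between them is established.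

Compound 3 `COc1ccc(C(=O)/C(=C\c2ccccc2Cl)COC(=O)c2ccccc2)cc1` differs from compound 2 by the two compounds have the same atoms and bonds and differ only in configuration as drawn: 1 of 1 stereo elements differ; a double bond is drawn E in compound 2 and Z in compound 3. Going by the values given here, no measured step changes a double-bond geometry; the only step available, a 1.5-fold lower number from compound 1 to compound 2 (0.18 log units; within the scatter), replaces the group on the double-bonded chain carbon and is itself within the scatter. There is therefore no basis for expecting a shift beyond the scatter in either direction, and the range must stay wide.

The step from compound 2 to compound 3 is expected to be no change at the digits printed from compound 2 to compound 3 (within the scatter). Compound 3 is accordingly estimated at 9000 nM, with a range from 3000 nM to 27000 nM.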

Compound 3, half-maximal inhibitory concentration: 36000 nM
For compound 3 the middle estimate is 4.0-fold (0.60 log units) below the measured one; the measured number lies above the stated range.
By their numbers in this assay, from the lowest: compounds 2 and 1 (each within the scatter of the next); then compound 3.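

In this assay, for the compounds shown here, the change of the double bond from E to Z gives a 4.0-fold higher number from compound 2 to compound 3 (0.60 log units; beyond the scatter) and this is the first step beyond the scatter. The earlier replacement of cyclohexyl by 2-chlorophenyl gave a 1.5-fold lower number from compound 1 to compound 2 (0.18 log units; within the scatter) and so set no order, whereas the geometry of that same double bond does separate two compounds, with the E form as the stronger inhibitor of the pair. The step can be assigned to configuration alone, because nothing else separates the pair: the fact that compounds 2 and 3 differ only in the configuration as drawn.

The compounds shown leave open whether the same geometry step holds with cyclohexyl on the double-bonded chain carbon, since only one pair of geometric forms is available. Also open, going by these compounds, is how an amine or a carboxylic acid at that carbon would read in either geometry.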